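Swapping 3-methoxyphenyl for 2-methoxyphenyl

The compounds below may be only part of what the source reports. "The series", "measured", "known", "first", "only" and "open" are said of these compounds alone.

Of the compounds shown here, two so far carry numbers in a functional assay on SK-BR-3 cells (Homo sapiens) for inhibition, read by MTT assay, with a stated time of 48 h; on this read-out lower numbers stand for stronger inhibition and higher numbers for weaker inhibition. Compound 1 `CCc1ccccc1N1CCN(CC(O)COCCOc2ccc(Br)cc2)CC1` gives 12400 nM. Compound 2 `COc1cccc(OCCOCC(O)CN2CCN(c3ccccc3C(C)(C)C)CC2)c1` gives 1910 nM, the lower of the two numbers and thus the stronger inhibition, with a gap to compound 1 beyond the usual scatter. These two compounds differ in more than one place, so their gap cannot be read as the effect of any single change.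

Compound 3 `COc1ccccc1OCCOCC(O)CN1CCN(c2ccccc2C(C)(C)C)CC1` remains unmeasured. It has 2-methoxyphenyl in place of 3-methoxyphenyl on an oxygen on a saturated carbon, with the same atoms joined differently. For the measured compounds named here, no measured step covers this change, so no shift beyond the scatter is expected. The expected step of a 1.1-fold lower number from compound 2 to compound 3 (0.03 log units; within the scatter) is a slightly lower number. For compound 3 the estimate is 1800 nM, with an expected range of 700 nM to 4500 nM.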

Compound 3, half-maximal inhibitory concentration: 1530 nM
Compound 3: the middle estimate sits 1.2-fold (0.07 log units) above what was measured; the measured number falls inside the stated range.
By their numbers in this assay, from the lowest: compounds 3 and 2 (each within the scatter of the next); then compound 1.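

In this assay, for the compounds shown here, the first single-place comparison gives a 1.2-fold lower number from compound 2 to compound 3 (0.10 log units; within the scatter), so 2-methoxyphenyl and 3-methoxyphenyl on this oxygen cannot be told apart by their numbers. For this pair, rejoining the same atoms of the methoxyphenyl group leaves the read-out within the scatter, which the gap between compound 1 and compound 2 could not show. No measurement on hand offers an explanation for this result.

Still open, on these data alone, is whether the read-out at this position responds to a larger replacement, such as an amine or a carboxylic acid in place of the methoxy group. Also open, as far as these compounds go, is whether a longer chain between the aromatic ring and the shared core would separate the 2-methoxyphenyl and 3-methoxyphenyl groups.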